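The compounds below may be only part of what the source reports. "The series", "measured", "known", "first", "only" and "open" are said of these compounds alone.

Measured compounds in a functional assay on PC-3 cells (Homo sapiens) for inhibition, read by sulforhodamine B assay, with a stated time of 48 h, tested at 100 uM; on this read-out higher numbers stand for more inhibition of growth at the one concentration tested and lower numbers for less inhibition of growth:

compound 1 `O=c1c(C2N=C(c3ccccc3)SS2)coc2ccc(F)cc12`: 32%
compound 2 `O=c1c(C2N=C(c3ccccc3)SS2)coc2cc(Cl)ccc12`: 81%

Compound 2 stands highest of the two numbers in this assay. Among the compounds with values here, its nearest neighbour is compound 1, whose value lies below it by a gap that goes beyond the usual scatter of repeated measurements; no direct step between the two is reported, since they differ in more than one place, so only their two values can be compared.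

Compound 3 `O=c1c(C2N=C(c3ccccc3)SS2)coc2ccccc12` has not been measured in this assay. It differs from compound 2 by hydrogen in place of chloro on an aromatic carbon. Within the data shown here, no measured pair shows this change, so its size can only be expected. Among the two measured compounds, compound 2 with its chloro gives 81% and compound 1, which carries a fluoro instead, gives 32%, so a substituent on that ring appears to matter, though no compound without one has yet been tested.

The step from compound 2 to compound 3 is expected to be a loss, estimated at a number 41 percentage points lower from compound 2 to compound 3 (beyond the scatter). For compound 3 the estimate is 40%, with a range from 15% to 70%.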

Compound 3, percent growth inhibition at one concentration: 23%
The estimate for compound 3 lay 17 percentage points above the measured number; the range from low to high includes it.
By their numbers in this assay, from the lowest: compounds 3 and 1 (each within the scatter of the next); then compound 2.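

In this assay, within the data shown here, hydrogen in place of chloro on this aromatic carbon gives a number 58 percentage points lower from compound 2 to compound 3 (beyond the scatter) and thereby isolates the change for the first time: within this pair, the high value depends on the chloro at this position of the shared core. Hydrogen in place of fluoro gives a number 9 percentage points lower from compound 1 to compound 3 (within the scatter) and so shows no effect that can be told apart from the usual scatter, which means that a halogen on this ring does not by itself raise the value, since the fluoro of compound 1 goes against any such pattern. Nothing at hand bears on what lies behind the large effect of the chloro.

As far as these compounds go, it remains open whether the effect belongs to chloro alone, or whether a bromo, a methoxy or an amine on the same aromatic carbon would give a similar value. From the compounds shown here alone, it is also open whether fluoro on that carbon would behave like chloro, whether chloro on the carbon bearing the fluoro of compound 1 would keep its effect, and whether the effect would persist with a carboxylic acid on the phenyl ring.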